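The compounds below may be only part of what the source reports. "The series", "measured", "known", "first", "only" and "open" are said of these compounds alone.

Measured compounds in an ADME assay on HEK293 cells (Homo sapiens) for cytotoxicity, read by fluorescence and resazurin assay, with a stated time of 24 h; a higher number here means that more compound is tolerated, a lower number that less compound is tolerated:
- compound 1 `O=S1(=O)C=C(Sc2nnc(C3CCCCC3)o2)c2ccccc21`: 3000 nM
- compound 2 `Cc1ccc(-c2nnc(SC3=CS(=O)(=O)c4ccccc43)o2)cc1`: 3000 nM

Compound 1 stands level with compound 2 in this assay at the digits shown. For the measured compounds named here, the one recorded step, no change at the digits printed from compound 1 to compound 2 (within the scatter), puts 4-methylphenyl in place of cyclohexyl on an aromatic carbon and leaves the read-out where it was, within the scatter.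

Compound 3 `O=S1(=O)C=C(Sc2nnc(-c3cccc(Cl)c3)o2)c2ccccc21` is not yet measured. It differs from compound 1 as follows: 3-chlorophenyl in place of cyclohexyl on an aromatic carbon. The step from compound 1 to compound 2 bears directly on this change: it too exchanges the cyclohexyl for a six-membered aromatic ring on the same aromatic carbon of the shared core, and that step was flat within the scatter. Going by the values given here, with only this one comparison to go on, a 3-chlorophenyl in the same place is expected to behave much as the 4-methylphenyl of compound 2 did, and no step beyond the scatter is expected in this assay in either direction.

Compound 3 is therefore estimated at 3000 nM in this assay, with a range from 1000 nM to 9000 nM. This amounts to an expected no change at the digits printed from compound 1 to compound 3 (within the scatter).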

Compound 3, half-maximal cytotoxic concentration: 6000 nM
Compound 3: middle estimate off by 2.0-fold (0.30 log units), on the low side, within the range that was stated.
By their numbers in this assay, from the lowest: compounds 1, 2 and 3 (each within the scatter of the next).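

In this assay, the comparison with the cyclohexyl of compound 1 gives a 2.0-fold higher number from compound 1 to compound 3 (0.30 log units; within the scatter) for a second aromatic replacement, this one carrying a chlorine on the ring. The series also now has its first comparison between two substituted phenyl groups, 3-chlorophenyl against 4-methylphenyl, with a 2.0-fold higher number from compound 2 to compound 3 (0.30 log units; within the scatter) as the result. Neither step leaves the scatter, so at this aromatic carbon of the five-membered aromatic ring the read-out does not separate the three groups, and nothing measured here explains the read-out at this position.

The compounds shown leave open whether any group at this place moves the read-out beyond the scatter, for example a carboxylic acid or an amine on the phenyl ring, a longer alkyl chain in place of the ring, or 4-chlorophenyl as the direct counterpart of 3-chlorophenyl. They also leave open whether a change elsewhere on the shared core would affect how much compound is tolerated, as all three compounds differ in this one place only.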